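Swapping the substituent beside the amide: methoxy to trifluoromethyl

The source may report more compounds than this note shows. Statements on the series, on what has been measured and on what is new or still open speak of the compounds shown alone.

Measured so far:
compound 1, `Cc1cc(-c2sc(Cc3cccc(C(F)(F)F)c3)nc2C)ccc1C(N)=O`: 86%
compound 2, `COc1cc(-c2sc(Cc3cccc(C(F)(F)F)c3)nc2C)ccc1C(N)=O`: 88%

In a functional assay on cells for agonist activity at G-protein coupled receptor 52 (Homo sapiens), read by AlphaScreen and cAMP accumulation, with a stated time of 30 min (on this read-out higher numbers stand for larger maximal responses and lower numbers for smaller maximal responses), compound 1 gives 86% and compound 2 gives 88%. The one step between them, a number 2 percentage points higher from compound 1 to compound 2 (within the scatter), lies within the scatter, so the two compounds sit together and neither stands apart on the numbers shown.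

Compound 3, `Cc1nc(Cc2cccc(C(F)(F)F)c2)sc1-c1ccc(C(N)=O)c(C(F)(F)F)c1`, has not been measured. It differs from compound 2 by trifluoromethyl in place of methoxy on an aromatic carbon, at the position ortho to a carbamoyl group and meta to a large group. For the measured compounds named here, the only step that bears on this position is the one from compound 1 to compound 2, and it was within the scatter, so there is no measured ground for expecting more than a small shift in this assay. Compound 3 is therefore estimated to give about 85%, between 65% and 100%, a step of a number 3 percentage points lower from compound 2 to compound 3 (within the scatter) expected to stay within the scatter.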

Compound 3, largest response reached (Emax), in percent of the reference or control that the assay uses: 92%
Beside the measured number, compound 3's estimate is 7 percentage points below it; the range from low to high includes it.
By their numbers in this assay, from the lowest: compounds 1, 2 and 3 (each within the scatter of the next).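

In this assay, a number 4 percentage points higher from compound 2 to compound 3 (within the scatter) and a number 6 percentage points higher from compound 1 to compound 3 (within the scatter) both lie within the scatter, so at this position, ortho to a carbamoyl group, methyl, methoxy and trifluoromethyl cannot be told apart. Trifluoromethyl carries no hydrogen-bond acceptor where methoxy carries one, so among these compounds a maximal response of this size does not depend on an acceptor in this place. Nothing at hand explains why the three groups sit together. The compounds shown leave open whether an amine, a hydroxyl or a carboxylic acid in this place would also stay within this band, or would instead move the response beyond the scatter. They also leave open how much of each compound is needed to reach this response, since only the largest response is given here.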